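The source may hold more compounds than are shown below. What is called first, only, known or untested is meant among the compounds shown, and "the series" means these compounds.

In a functional assay on SF-295 cells (Homo sapiens) for cytotoxicity (on this read-out higher numbers stand for weaker inhibition of growth and lower numbers for stronger inhibition of growth), compound 1 `CCc1ccc(/N=C/c2cc(OC)c(OC)c(OC)c2)cc1` reaches only a limit of the assay, > 100000 nM. Going by the values given here, compound 2 `COc1ccc(/N=C/c2cc(OC)c(OC)c(OC)c2)cc1` gives 52700 nM, the only exact number so far. Compound 3 `CCOc1ccc(/N=C/c2cc(OC)c(OC)c(OC)c2)cc1` differs from compound 2 by methyl in place of hydrogen on a saturated chain carbon bound to an oxygen on an aromatic ring, which turns methoxy into ethoxy. Among the compounds with values here, the one measured step, an at least 1.8-fold lower number from compound 1 to compound 2 (0.27 log units; that floor lies within the scatter), is a different change and rests on (the limit of > 100000 nM in this assay, at which 1 of the 2 values shown sits), so it gives only a weak guide to size. No step beyond the scatter is therefore expected in this assay, in either direction. The expected step is a 1.1-fold higher number from compound 2 to compound 3 (0.06 log units; within the scatter). For compound 3 the estimate is 60000 nM, with an expected range from 25000 nM to 100000 nM.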

Compound 3, concentration for 50% growth inhibition: > 100000 nM
Compound 3: a limit, no number (the forecaster's own chance of this, stated with the estimate: 25%); middle value at least 1.6-fold (0.22 log units) from the limit.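

In this assay, adding methyl to the saturated chain carbon bound to an oxygen on an aromatic ring, which turns methoxy into ethoxy, gives an at least 1.8-fold higher number from compound 2 to compound 3 (0.27 log units; that floor lies within the scatter). As far as these compounds go, the value of compound 3 is a limit and not a number, so the true size of this step remains unknown and may or may not exceed the usual scatter. The step between compound 1 and compound 3 cannot be read, because both values are limits: the limit of > 100000 nM in this assay, at which 2 of the 3 values shown sit.

Still open, from the compounds shown here alone, is whether a longer chain or an amine at this place would give an exact number rather than a limit. Going by these compounds, it is also open whether any such group would give a lower number than compound 2, which has 52700 nM.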